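The source may hold more compounds than are shown below. What is called first, only, known or untested is meant among the compounds shown, and "the series" means these compounds.

Among the measured compounds shown here, in a physicochemical assay for lipophilicity, read by spectrophotometry, measured as octanol-water partition, at pH 7.4 (a higher number here means a more lipophilic compound, a lower number a more polar compound), compound 1 `CCOc1cc(CN2CCC(NC(=O)c3cncc(C)c3)CC2)ccc1C` gives 3.03, the lowest of the three numbers measured so far. Compound 2 `CCOc1cc(CN2CCC(NC(=O)c3ccc(NC(C)C)nc3)CC2)cc(OCC)c1F` stands higher at 3.39, and compound 3 `CCOc1cc(CN2CCC(NC(=O)c3cncc(C)c3)CC2)ccc1-c1ccc(F)cc1` stands highest at 4.1.

The next compound to be measured, compound 4 `CCOc1cc(CN2CCC(NC(=O)c3ccc(N)nc3)CC2)ccc1C`, keeps the core of compound 1 and differs in one place, on a carbonyl carbon: 6-aminopyridin-3-yl in place of 5-methylpyridin-3-yl on a carbonyl carbon. In words, 6-aminopyridin-3-yl takes the place of 5-methylpyridin-3-yl. Both groups are six-membered aromatic rings with no net charge, but hydrogen-bond donors and acceptors increase with the change.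

For the measured compounds named here, only one measured step is available: a number 1.07 log units higher from compound 1 to compound 3 (beyond the scatter). This large step came from 4-fluorophenyl replacing methyl on an aromatic carbon, a different place in the molecule. It shows how far one change can move this scale, but it does not show what the new change will do. Compound 2 differs from compound 1 in more than one place, so it offers no clean comparison. Going by the values given here, no measured step swaps the group now in question, so the expectation remains loose.

With more hydrogen-bond donors and acceptors entering, a moderate downward step is expected, and the estimate is a number 0.43 log units lower from compound 1 to compound 4 (beyond the scatter). Compound 4 is therefore expected at 2.6, with an estimated range from 2.1 to 3.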

Compound 4, distribution coefficient: 2.24
Estimate against measurement, compound 4: 0.36 log units above, within the range that was stated.
By their numbers in this assay, from the lowest: compound 4; then compound 1; then compound 2; then compound 3.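

In this assay, placing 6-aminopyridin-3-yl instead of 5-methylpyridin-3-yl on the carbonyl carbon gives a number 0.79 log units lower from compound 1 to compound 4 (beyond the scatter). The only earlier step, at a different place in the molecule, went the other way, a number 1.07 log units higher from compound 1 to compound 3 (beyond the scatter), so the number can now be seen to move both up and down from compound 1, and this site on the carbonyl carbon is shown to affect it as well. The two groups match in heavy atoms and ring size, and they differ in that one ring carbon's worth of the group becomes nitrogen and the count of hydrogen-bond donors and acceptors goes up, but nothing measured here says what lies behind the step.

This single swap removes a methyl and brings in an amine together, so a bare pyridin-3-yl group, carrying neither, would be needed to tell their shares apart. On these data alone, it also remains open whether a longer chain on the amine, or a carboxylic acid in its place, would move the number further, and whether the same swap would give a similar step on the core of compound 3.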